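From trifluoromethyl to acetyl on an aromatic carbon

The source may hold more compounds than are shown below. What is called first, only, known or untested is meant among the compounds shown, and "the series" means these compounds.

In a functional assay on the whole organism for positive allosteric modulation, with Mus musculus as the target (on this read-out higher numbers stand for an effect only at larger amounts of compound and lower numbers for an effect already at smaller amounts), compound 1 (`CCC(=O)N(c1ccc(OC)cc1)C1CCCC1N(C)C`) gives 30 mg/kg; 30 mg/kg (2 entries) in both of its entries, while compound 2 (`CCC(=O)N(c1cccc(F)c1)C1CCCC1N(C)C`) gives 0.4 mg/kg. Compound 3 (`CCC(=O)N(c1ccc(C(F)(F)F)cc1)C1CCCC1N(C)C`) gives 10 mg/kg, a number beyond the scatter above that of compound 2 and lower than that of compound 1. Compound 4 (`CCC(=O)N(c1ccc(C(C)=O)cc1)C1CCCC1N(C)C`) carries acetyl in place of trifluoromethyl on an aromatic carbon, para to a large group (acetyl in place of trifluoromethyl on an aromatic carbon). Compound 1 at 30 mg/kg; 30 mg/kg (2 entries) and compound 3 at 10 mg/kg both stand well above compound 2, so compound 4 is expected to stay near them. In this assay, no step beyond the scatter is expected, the estimated step being a 1.5-fold higher number from compound 3 to compound 4 (0.18 log units; within the scatter). Compound 4 is expected at 15 mg/kg, with an estimated range of 4 mg/kg to 50 mg/kg.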

Compound 4, dose for half-maximal effect: > 50 mg/kg
Compound 4: no number, only a limit; the forecaster's own chance of this, stated with the estimate: 10%; middle value at least 3.3-fold (0.52 log units) from the limit.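

Among the compounds shown, only this pair differs in one place, and it shows that the position para to a large group does not tolerate every change: in this assay, acetyl in place of trifluoromethyl gives an at least 5.0-fold higher number from compound 3 to compound 4 (0.69 log units; beyond the scatter). In this assay compound 4 gives > 50 mg/kg, which is a limit of the assay and not a number. The true size of the step therefore stays unknown, and only its lower bound can be read: the limit of > 50 mg/kg in this assay, at which 1 of the 4 values shown sits.

The compounds shown leave open how an amine, a carboxylic acid or a nitrile would read at this position. They also leave open whether a longer chain on the carbonyl would read like acetyl.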